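From phenyl to 4-bromophenyl in compound 1

The source may report more compounds than this note shows. Statements on the series, on what has been measured and on what is new or still open speak of the compounds shown alone.

For the measured compounds named here, in a functional assay on KB cells (Homo sapiens) for antiproliferative activity, read by sulforhodamine B assay, with a stated time of 3 days (a lower number here means that less compound is needed, a higher number that more compound is needed for the effect), compound 1 `CCCC1=C(OC)C(CCC)(CCC)C(=O)/C(=C(O)\C=C\c2ccccc2)C1=O` gives 4.6 uM, the lower of the two numbers known so far, and compound 2 `CCCC1=C(OCCC(C)C)C(CCC)(CCC)C(=O)/C(=C(O)\C=C\c2ccccc2)C1=O` gives 10.6 uM. Compound 3 `CCCC1=C(OC)C(CCC)(CCC)C(=O)/C(=C(O)\C=C\c2ccc(Br)cc2)C1=O` has not yet been measured. It differs from compound 1 by bromo in place of hydrogen on an aromatic carbon, turning phenyl into 4-bromophenyl: bromo in place of hydrogen on an aromatic carbon. Going by the values given here, the only measured step, a 2.3-fold higher number from compound 1 to compound 2 (0.36 log units; beyond the scatter), is modest and beyond the scatter, but it concerns the chain on the oxygen, not the aromatic ring. Among the compounds with values here, no measured compound carries a substituent on that ring, so the evidence is indirect. A small step is therefore expected in this assay, with no firm direction and possibly nothing beyond the scatter. The estimated change is a 1.2-fold lower number from compound 1 to compound 3 (0.06 log units; within the scatter). For compound 3 the expected value is 4 uM, with an estimated range of 1.6 uM to 10 uM.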

Compound 3, concentration for half-maximal effect: 1.8 uM
Estimate against measurement, compound 3: 2.2-fold (0.35 log units) above, within the range that was stated.
By their numbers in this assay, from the lowest: compound 3; then compound 1; then compound 2.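

Until now, both measured compounds carried the same unsubstituted phenyl, so nothing showed whether this ring responds to substitution. In this assay the change from phenyl to 4-bromophenyl gives a 2.6-fold lower number from compound 1 to compound 3 (0.41 log units; beyond the scatter) and so shows that the position is not indifferent to a bromo: a single added atom on this aromatic carbon moves the number beyond the scatter, and toward less compound needed. Nothing available explains this shift.

The compounds shown leave open whether the lower number is particular to bromo or would also appear with fluoro, methoxy or an amine on the same carbon. They also leave open whether the bromo step would hold with the longer chain on the oxygen that compound 2 carries.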